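The source may hold more compounds than are shown below. What is called first, only, known or untested is meant among the compounds shown, and "the series" means these compounds.

Compound 1 `O=C(NCCNS(=O)(=O)c1ccc(-c2ccccc2Oc2ccc([N+](=O)[O-])c([N+](=O)[O-])c2)s1)Nc1cc(Cl)cc(Cl)c1` gives 2300 nM in a functional assay on HL-60 cells (Homo sapiens) for inhibition, read by CCK-8 assay, with a stated time of 48 h; on this read-out higher numbers stand for weaker inhibition and lower numbers for stronger inhibition.
Compound 2 `COc1ccc(NC(=O)NCCNS(=O)(=O)c2ccc(-c3ccccc3Oc3ccc([N+](=O)[O-])c([N+](=O)[O-])c3)s2)cc1` gives 5400 nM.
Compound 3 `COc1ccc(NC(=O)NCCNS(=O)(=O)c2ccc(-c3ccccc3OCc3ccccc3)s2)cc1` reaches only the limit of the assay, > 50000 nM.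

Among the two full numbers in this assay, compound 2 stands highest; its nearest neighbour is compound 1, and that step, a 2.3-fold higher number from compound 1 to compound 2 (0.37 log units; beyond the scatter), was modest. Compound 4 `COc1cccc(NC(=O)NCCNS(=O)(=O)c2ccc(-c3ccccc3Oc3ccc([N+](=O)[O-])c([N+](=O)[O-])c3)s2)c1` differs from compound 2 by 3-methoxyphenyl in place of 4-methoxyphenyl on an amide-type nitrogen. Among the compounds with values here, only one measured step touches the same amide-type nitrogen, a 2.3-fold higher number from compound 1 to compound 2 (0.37 log units; beyond the scatter), and it swapped a quite different group; no measured pair compares 4-methoxyphenyl with 3-methoxyphenyl. The change in compound 4 is therefore expected to bring no step beyond the scatter, a 1.1-fold lower number from compound 2 to compound 4 (0.03 log units; within the scatter). Compound 4 is estimated at 5000 nM, with a range from 2000 nM to 14000 nM.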

Compound 4, half-maximal inhibitory concentration: 6700 nM
Beside the measured number, compound 4's estimate is 1.3-fold (0.13 log units) below it; the measured number falls inside the stated range.
By their numbers in this assay, from the lowest: compound 1; then compounds 2 and 4 (each within the scatter of the next). At a limit, above all of these: compound 3.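

Swapping 4-methoxyphenyl for 3-methoxyphenyl on this amide-type nitrogen leaves the number within the scatter (a 1.2-fold higher number from compound 2 to compound 4 (0.09 log units; within the scatter)), so these compounds show no dependence on where the methoxy group sits. The 3,5-dichlorophenyl group of compound 1 still gives the lower number, now against this methoxy isomer as well (a 2.9-fold higher number from compound 1 to compound 4 (0.46 log units; beyond the scatter)). No measurement shown here explains either step.

Still open, from the compounds shown here alone, is how 2-methoxyphenyl or plain phenyl would read at this nitrogen. A phenyl ring carrying an amine or a carboxylic acid also remains untested among the compounds shown.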